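This account rests on a few compounds, and the source may have more. Where it says the series, first, only, none or still open, it means among the compounds named here.

Compound 1 `O=C(O)CCCCCCN1C(=O)CCC1CCC(O)CCc1ccccc1` gives a limit in an assay on HEK293 cells for binding affinity to prostaglandin E2 receptor EP4 subtype (Rattus norvegicus) (a higher number here means a weaker inhibitor, a lower number a stronger inhibitor), > 3200 nM.
Compound 2 `O=C(O)c1ccc(CCCN2C(=O)CCC2CCC(O)Cc2ccc(F)cc2)cc1` gives 2770 nM in this assay.
Compound 3 `O=C(O)CCCCCCN1C(=O)CCC1CCC(O)Cc1cccc(Cl)c1` gives 22 nM in this assay.

Compound 3 stands lowest of the two numbers shown in this assay; the nearest number is that of compound 2, which lies far higher and beyond the scatter. For compound 1 the assay reports only a limit, (the limit of > 3200 nM in this assay, at which 1 of the 3 values shown sits). Going by the values given here, the single measured step, an at least 140-fold lower number from compound 1 to compound 3 (2.16 log units; beyond the scatter), concerns the group on the saturated chain carbon two bonds along the chain from an oxygen on a saturated carbon, not the acid-bearing chain, so it does not bear directly on the change now followed.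

Compound 4 `O=C(O)c1ccc(CCCN2C(=O)CCC2CCC(O)Cc2cccc(Cl)c2)cc1` differs from compound 3 in 4-carboxyphenyl in place of 3-carboxypropyl on a saturated chain carbon, three bonds along the chain from an amide-type nitrogen in a ring. Among the compounds with values here, no measured pair isolates this change. Within the data shown here, compound 2 carries the same 4-carboxyphenyl group but a different ring on the other chain, so its value tells only that a compound with this acid-bearing group can sit far higher than compound 3. The step from compound 3 to compound 4 is therefore expected to raise the number, roughly by a 14-fold higher number from compound 3 to compound 4 (1.13 log units; beyond the scatter), because compound 2 with the same 4-carboxyphenyl gives 2770 nM. Compound 4 is estimated at 300 nM, within a wide range from 40 nM to 2500 nM.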

Compound 4, half-maximal inhibitory concentration: 42 nM
Compound 4: the middle estimate sits 7.1-fold (0.85 log units) above what was measured, and the stated range covers the measured number.
By their numbers in this assay, from the lowest: compounds 3 and 4 (each within the scatter of the next); then compound 2. At a limit, above all of these: compound 1.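

In this assay, 4-carboxyphenyl in place of 3-carboxypropyl on a saturated chain carbon, three bonds along the chain from an amide-type nitrogen in a ring, gives a 1.9-fold higher number from compound 3 to compound 4 (0.28 log units; within the scatter), so with 3-chlorophenyl on the other chain the aromatic ring and the open chain cannot be told apart in this assay. With 4-carboxyphenyl present in both compounds, 3-chlorophenyl in place of 4-fluorophenyl gives a 66-fold lower number from compound 2 to compound 4 (1.82 log units; beyond the scatter), which shows that the 4-carboxyphenyl group does not by itself bring a number as high as the one first seen with it. The measurements shown give no reason for either finding.

The compounds shown leave open whether 3-carboxypropyl and 4-carboxyphenyl also match when 4-fluorophenyl sits on the other chain, as the equivalence is seen only with 3-chlorophenyl. They also leave open how a 3-carboxyphenyl group, a tetrazole in place of the carboxylic acid, or a longer chain carrying the 4-carboxyphenyl group would read in this assay.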